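This account rests on a few compounds, and the source may have more. Where it says the series, first, only, none or still open, it means among the compounds named here.

Measured in a functional assay on HeLa cells (Homo sapiens) for cytotoxicity, read by WST assay, with a stated time of 48 h; on this read-out lower numbers stand for stronger inhibition and higher numbers for weaker inhibition:
- Compound 1 `Oc1ccccc1/C=C/C[C@H]1C[C@@H]([C@@H](O)c2ccccc2)CO[C@@H]1c1ccccc1`: 21800 nM
- Compound 2 `COc1cccc(/C=C/C[C@H]2C[C@@H]([C@@H](O)c3ccccc3)CO[C@@H]2c2ccccc2)c1`: 10900 nM

For the measured compounds named here, compound 2 holds the lower of only two numbers, but it cannot be separated from compound 1. Compound 3 `O[C@@H](c1ccccc1)[C@H]1CO[C@H](c2ccccc2)[C@@H](C/C=C/C2CCCC2)C1` has cyclopentyl in place of 3-methoxyphenyl on a double-bonded chain carbon bound to a double-bonded chain carbon. Going by the values given here, the only guide is a 2.0-fold lower number from compound 1 to compound 2 (0.30 log units; within the scatter), a change at this same place. Among the compounds with values here, no measured compound has a non-aromatic ring there, so this guide is weak. The expected result in this assay is a 1.1-fold higher number from compound 2 to compound 3 (0.04 log units; within the scatter), with no step beyond the scatter and no favoured direction. For compound 3 the estimated value is 12000 nM, with an expected range of 5000 nM to 30000 nM.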

Compound 3, half-maximal inhibitory concentration: 9330 nM
For compound 3 the middle estimate is 1.3-fold (0.11 log units) above the measured one; the range from low to high includes it.
By their numbers in this assay, from the lowest: compounds 3, 2 and 1 (each within the scatter of the next, the first and the last beyond it).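

In this assay, a non-aromatic carbon ring can stand at this place without a clear loss: a 1.2-fold lower number from compound 2 to compound 3 (0.07 log units; within the scatter) leaves cyclopentyl and 3-methoxyphenyl inseparable. For the compounds shown here, the comparison with the hydroxylated aryl group gives the first step in this set beyond the scatter, though only a modest one (with a 2.3-fold lower number from compound 1 to compound 3 (0.37 log units; beyond the scatter)), while compound 2 stays within the scatter of both neighbours. An aromatic ring at this place is therefore not required to keep the number in this range. From the compounds shown here alone, whether an amine or a carboxylic acid here would move the number remains open, as does the effect of a longer chain. No evidence is available to explain these results.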